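The source may hold more compounds than are shown below. What is called first, only, known or untested is meant among the compounds shown, and "the series" means these compounds.

In an ADME assay on microsomes from liver (Homo sapiens) for pharmacokinetics, read by LC-MS, using NADPH, with a stated time of 45 min, tested at 1 uM (a higher number here means faster removal of the compound, a lower number slower removal), compound 3 (`CNC(=O)Nc1nccc(COc2cc(OC)c3nc(N[C@H]4CCCC[C@@H]4O)sc3c2)n1`) gives 23 mL/min/kg. This lies within the scatter of compound 1 (`Nc1nccc(COc2cc(Cl)c3nc(N[C@@H]4CCCC[C@H]4O)sc3c2)c1Cl`) at 32 mL/min/kg, while compound 2 (`COc1cc(OCc2ccnc(N)n2)cc2sc(N[C@H]3CCCC[C@@H]3O)nc12`) gives a lower number, 9.5 mL/min/kg, beyond the scatter. Compound 4 (`COc1cc(OCc2ccnc(Nc3ccn(C)n3)n2)cc2sc(N[C@H]3CCCC[C@@H]3O)nc12`) is the next to be read, with one change from compound 3: 1-methyl-1H-pyrazol-3-yl in place of methylcarbamoyl on a nitrogen on an aromatic ring. Among the compounds with values here, the only measured step at this nitrogen is a 2.4-fold higher number from compound 2 to compound 3 (0.38 log units; beyond the scatter), a modest step seen when methylcarbamoyl replaces hydrogen. Within the data shown here, compound 1 differs from the others in more than one place and offers no single-change step. Among the measured compounds shown here, no measured compound carries 1-methyl-1H-pyrazol-3-yl, so the data give no direct guide to this group. No step beyond the scatter is therefore expected in this assay, and no firm direction can be assigned. The expected step is a 1.1-fold higher number from compound 3 to compound 4 (0.04 log units; within the scatter). For compound 4 the estimate is 25 mL/min/kg, with an expected range of 11 mL/min/kg to 50 mL/min/kg.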

Compound 4, clearance: 17 mL/min/kg
Beside the measured number, compound 4's estimate is 1.5-fold (0.17 log units) above it, and the stated range covers the measured number.
By their numbers in this assay, from the lowest: compounds 2, 4, 3 and 1 (each within the scatter of the next, the first and the last beyond it).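

In this assay, the nitrogen on an aromatic ring accepts a heteroaromatic group as readily as a urea-type group: 1-methyl-1H-pyrazol-3-yl in place of methylcarbamoyl gives a 1.4-fold lower number from compound 3 to compound 4 (0.13 log units; within the scatter) and so does not separate the two groups. Against hydrogen on that nitrogen, the new group gives a 1.8-fold higher number from compound 2 to compound 4 (0.25 log units; within the scatter) while methylcarbamoyl gives a 2.4-fold higher number from compound 2 to compound 3 (0.38 log units; beyond the scatter) and thus only methylcarbamoyl has a step from hydrogen printed as beyond the scatter, so the earlier rise does not extend to every group placed here. No measurement available explains these steps.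

The compounds shown leave open how methyl, acetyl or a pyridin-2-yl ring on this nitrogen would read in this assay. They also leave open whether these steps carry over to the core of compound 1, which bears chlorine.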